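Removing a Methyl from the Aryl Ether of Compound 3

A few compounds are considered here, and "the series" means these few. Any claim that something is new, unique, unknown or untested is made for them only; others in the source may bear on it.

Of the compounds shown here, three sharing one core have been tested in a functional assay on UO-31 cells (Homo sapiens) for inhibition, read by sulforhodamine B assay, with a stated time of 48 h; a lower number here means a stronger inhibitor of growth, a higher number a weaker inhibitor of growth. Compound 1 `O=C(Nc1cccc(-n2cc(-c3ccncc3)c(-c3ccc(Cl)c(O)c3)n2)c1)Nc1cccc(C(F)(F)F)c1` gives 1860 nM, compound 2 `O=C(Nc1cccc(-n2cc(-c3ccncc3)c(-c3ccc(Cl)c(O)c3)n2)c1)Nc1ccc(Cl)c(Cl)c1` gives 1250 nM, and compound 3 `COc1cc(-c2nn(-c3cccc(NC(=O)Nc4ccc(Cl)c(C(F)(F)F)c4)c3)cc2-c2ccncc2)ccc1Cl` gives 865 nM, the lowest of the three numbers, though only its gap to compound 1 lies beyond the scatter; its gap to compound 2 does not. Among the compounds with values here, the single measured step, a 1.5-fold lower number from compound 1 to compound 2 (0.17 log units; within the scatter), concerns the aryl group on the urea and says nothing about the ether. Within the data shown here, compound 4 `O=C(Nc1cccc(-n2cc(-c3ccncc3)c(-c3ccc(Cl)c(O)c3)n2)c1)Nc1ccc(Cl)c(C(F)(F)F)c1` keeps everything of compound 3 except (hydrogen in place of methyl on an oxygen on an aromatic ring), so no measured step bears on this change, and its size in this assay must be guessed. Compound 4 is expected to give about 1100 nM, within 450 nM to 2700 nM, a step of a 1.3-fold higher number from compound 3 to compound 4 (0.10 log units; within the scatter).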

Compound 4, concentration for 50% growth inhibition: 777 nM
The estimate for compound 4 lay 1.4-fold (0.15 log units) above the measured number; the measured number falls inside the stated range.
By their numbers in this assay, from the lowest: compounds 4, 3, 2 and 1 (each within the scatter of the next, the first and the last beyond it).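

In this assay, the methyl on this oxygen can give way to hydrogen with no change beyond the scatter (a 1.1-fold lower number from compound 3 to compound 4 (0.05 log units; within the scatter)). Within the data shown here, with hydroxy in place, trifluoromethyl in place of chloro on an aromatic carbon also stays within the scatter (a 1.6-fold lower number from compound 2 to compound 4 (0.21 log units; within the scatter)), whereas chloro in place of hydrogen on an aromatic carbon gives the one new step that clears it, and only modestly (a 2.4-fold lower number from compound 1 to compound 4 (0.38 log units; beyond the scatter)). Nothing measured here accounts for the size of these steps.

From the compounds shown here alone, whether an ethyl group on this oxygen, or an amine in place of the oxygen, would leave the number as little changed remains open.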